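From amino to acetamido on compound 1

The compounds below may be only part of what the source reports. "The series", "measured", "known", "first", "only" and "open" are said of these compounds alone.

Going by the values given here, in a functional assay on PC-3 cells (Homo sapiens) for inhibition, read by sulforhodamine B assay, with a stated time of 72 h (on this read-out lower numbers stand for stronger inhibition and higher numbers for weaker inhibition), compound 1 `Nc1sc(-c2ccc(Cl)cc2)c(-c2ccc(Cl)cc2)c1C(=O)N1CCCCC1` gives 14300 nM, the highest of the three numbers measured so far. Compound 2 `Nc1sc(-c2ccc(Cl)cc2)c(-c2ccc(Cl)cc2)c1C(=O)NC1CCCCC1` gives 7300 nM, and compound 3 `Nc1sc(-c2ccc(Cl)cc2)c(-c2ccc(Cl)cc2)c1C(=O)NC1CCC(O)CC1` gives 5670 nM. The measured steps are a 2.0-fold lower number from compound 1 to compound 2 (0.29 log units; within the scatter), a 2.5-fold lower number from compound 1 to compound 3 (0.40 log units; beyond the scatter) and a 1.3-fold lower number from compound 2 to compound 3 (0.11 log units; within the scatter). All three concern the group on the carbonyl carbon, and none touches the amino group.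

Compound 4 `CC(=O)Nc1sc(-c2ccc(Cl)cc2)c(-c2ccc(Cl)cc2)c1C(=O)N1CCCCC1` differs from compound 1 at that untested place: acetyl in place of hydrogen on a nitrogen on an aromatic ring. The amino group of compound 1 thus becomes acetamido. Among the compounds with values here, no measured step shows what this change does, so the three steps offer only a loose guide to size. The largest of them, a 2.5-fold lower number from compound 1 to compound 3 (0.40 log units; beyond the scatter), is modest, and no clear direction can be drawn for the new change. A step beyond the scatter is therefore not expected, and the expected step is a 1.2-fold lower number from compound 1 to compound 4 (0.08 log units; within the scatter). The estimate for compound 4 is 12000 nM, with an expected range from 5000 nM to 30000 nM.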

Compound 4, half-maximal inhibitory concentration: 10300 nM
Beside the measured number, compound 4's estimate is 1.2-fold (0.07 log units) above it, and the stated range covers the measured number.
By their numbers in this assay, from the lowest: compounds 3, 2, 4 and 1 (each within the scatter of the next, the first and the last beyond it).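

In this assay, going by these compounds alone, the first change at the amino group gives a 1.4-fold lower number from compound 1 to compound 4 (0.14 log units; within the scatter), a step that stays within the scatter. Within the data shown here, this shows that, with the piperidin-1-yl amide in place, acetyl can stand on this nitrogen in place of hydrogen without a step beyond the scatter, which the earlier compounds could not show because all of their changes lay on the carbonyl carbon. Nothing available explains this result at the level of mechanism.

The compounds shown leave open whether acetyl on this nitrogen would give a similarly small step with the cyclohexylamino or (4-hydroxycyclohexyl)amino groups of compound 2 and compound 3. They also leave open what a larger group on this nitrogen, such as benzoyl or a longer acyl chain like butanoyl, would do.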